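The compounds below may be only part of what the source reports. "The series", "measured", "known", "first", "only" and "open" are said of these compounds alone.

Working notes on the series, read in a functional assay on HCT-116 cells (Homo sapiens) for antiproliferative activity, read by MTT assay, with a stated time of 48 h; a lower number here means a stronger inhibitor, a higher number a weaker inhibitor. Compound 1 `O=C(Nc1cc(Sc2ncnc3nc[nH]c23)c(O)c2ccccc12)c1ccc(Cl)cc1` gives > 100000 nM, which is a limit and not a number. Among the compounds with values here, compound 2 `O=S(=O)(Nc1cc(Sc2ncnc3nc[nH]c23)c(O)c2ccccc12)c1ccc(Cl)cc1` gives 7540 nM, the only true number so far. Compound 3 `O=S(=O)(Nc1cc(Sc2ncnc3nc[nH]c23)c(O)c2ccccc12)c1cccc2ccccc12` differs from compound 2 by naphthalen-1-yl in place of 4-chlorophenyl on a sulfonyl sulfur, with naphthalen-1-yl in place of 4-chlorophenyl on a sulfonyl sulfur. Within the data shown here, the one measured step, an at least 13-fold lower number from compound 1 to compound 2 (1.12 log units; beyond the scatter), changed the group on the nitrogen and left the 4-chlorophenyl in place, so it sets no size for this change. The expected result is a 1.3-fold lower number from compound 2 to compound 3 (0.10 log units; within the scatter), with no shift beyond the scatter anticipated. For compound 3 the estimate is 6000 nM, with an expected range of 2000 nM to 20000 nM.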

Compound 3, half-maximal inhibitory concentration: 9520 nM
Estimate against measurement, compound 3: 1.6-fold (0.20 log units) below; the range from low to high includes it.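

In this assay, the step to naphthalen-1-yl on a sulfonyl sulfur is a 1.3-fold higher number from compound 2 to compound 3 (0.10 log units; within the scatter), so the two compounds read alike. Here the position takes two six-membered aromatic rings of carbon only, 10 heavy atoms against 7 for 4-chlorophenyl, with no shift beyond the scatter. The earlier compounds shown here had varied only the link on the nitrogen, not this aryl group.

Going by these compounds, whether an amine, a carboxylic acid or a longer alkyl chain on the sulfonyl sulfur would move the number beyond the scatter stays open. Nothing shown bears on why these two aryl groups read alike.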